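The source may hold more compounds than are shown below. What is called first, only, known or untested is meant among the compounds shown, and "the series" means these compounds.

- compound 1 `CC(=O)N1c2ccccc2CCC1C(=O)Nc1ccccc1O`: 49700 nM
- compound 2 `O=C(Nc1ccccc1C(F)(F)F)C1CCc2ccccc2N1C(=O)c1cccc(Cl)c1`: 754 nM

In a functional assay on NUGC-3 cells (Homo sapiens) for cytotoxicity, read by sulforhodamine B assay, with a stated time of 72 h (a higher number here means a weaker inhibitor of growth, a lower number a stronger inhibitor of growth), compound 1, at 49700 nM, has the higher of the two numbers, and the gap down to compound 2, at 754 nM, lies beyond the usual scatter. These two compounds differ in more than one place, so their gap cannot be pinned on any single change.

Compound 3 `O=C(Nc1ccccc1O)C1CCc2ccccc2N1` differs from compound 1 in one place only: hydrogen in place of acetyl on a nitrogen on an aromatic ring in a ring. Within the data shown here, no measured pair here shows what such a change does in this assay. Among the measured compounds shown here, the only guide is the starting point, compound 1 at 49700 nM, which is the weaker of the two measured compounds. With so little evidence, the expectation is a small step, not beyond the scatter, and with no firm direction. The estimated change is a 1.2-fold lower number from compound 1 to compound 3 (0.09 log units; within the scatter). Compound 3 is expected to give about 40000 nM, with an estimated range from 12000 nM to 100000 nM.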

Compound 3, concentration for 50% growth inhibition: 2680 nM
Compound 3: the middle estimate sits 15-fold (1.17 log units) above what was measured; measured number below the stated range.
By their numbers in this assay, from the lowest: compound 2; then compound 3; then compound 1.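

Among these compounds, replacing the acetyl on the ring nitrogen of compound 1 with a plain hydrogen is the first single change that can be read at this position, and in this assay it gives a 19-fold lower number from compound 1 to compound 3 (1.27 log units; beyond the scatter) as a large step beyond the usual scatter. This shows that growth inhibition responds strongly to what sits on this nitrogen, and that within this pair the acetyl is not needed, since the compound carrying only hydrogen there is the stronger inhibitor of growth. No measurement shown here explains why removing the acetyl has so large an effect, so the reason remains unknown.

This single pair cannot show whether any group on this nitrogen would weaken growth inhibition or whether the result is particular to the acetyl. On these data alone, it remains open where a methyl, a longer chain such as propionyl, or an aminoethyl chain on the same nitrogen would fall compared with the hydrogen of compound 3.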